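Tolerated concentration: ring swap from pyridinyl to aminophenyl

The source may report more compounds than this note shows. Statements on the series, on what has been measured and on what is new or still open speak of the compounds shown alone.

Measured compounds:
- compound 1 `Cc1ccc(-c2cnc(Nc3ccc(C#N)cc3)nc2Oc2c(C)cc(C#N)cc2C)cc1`: 26100 nM in an ADME assay on MT4 cells (Homo sapiens) for cytotoxicity, read by MTT assay, with a stated time of 5 days; a lower number here means that less compound is tolerated, a higher number that more compound is tolerated
- compound 2 `Cc1cc(C#N)cc(C)c1Oc1nc(Nc2ccc(C#N)cc2)ncc1-c1ccoc1`: 4980 nM in this assay
- compound 3 `Cc1cc(C#N)cc(C)c1Oc1nc(Nc2ccc(C#N)cc2)ncc1-c1cccnc1`: 13500 nM in this assay

Compound 3 stands second highest of the three numbers in this assay; its separation from compound 1 is a 1.9-fold lower number from compound 1 to compound 3 (0.29 log units; within the scatter), and from compound 2 it is a 2.7-fold higher number from compound 2 to compound 3 (0.43 log units; beyond the scatter).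

Compound 4 `Cc1cc(C#N)cc(C)c1Oc1nc(Nc2ccc(C#N)cc2)ncc1-c1ccc(N)cc1` differs from compound 3 by 4-aminophenyl in place of pyridin-3-yl on an aromatic carbon. Among the measured compounds shown here, the step that bears most on this is the one between compound 1, which also carries a six-membered aromatic ring of carbon only at this carbon, and compound 3: a 1.9-fold lower number from compound 1 to compound 3 (0.29 log units; within the scatter). The furan-3-yl step, a 2.7-fold higher number from compound 2 to compound 3 (0.43 log units; beyond the scatter), was modest and points the other way. For compound 4 a step of about a 1.5-fold higher number from compound 3 to compound 4 (0.17 log units; within the scatter) in this assay is therefore expected, within the scatter. Compound 4 is estimated at 20000 nM, with a range of 7000 nM to 55000 nM.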

Compound 4, half-maximal cytotoxic concentration: 310 nM
For compound 4 the middle estimate is 65-fold (1.81 log units) above the measured one; the whole stated range lies above it.
By their numbers in this assay, from the lowest: compound 4; then compound 2; then compounds 3 and 1 (each within the scatter of the next).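

In this assay this aromatic carbon proves far more sensitive than the earlier ring swaps suggested, with a 44-fold lower number from compound 3 to compound 4 (1.64 log units; beyond the scatter) and a 16-fold lower number from compound 2 to compound 4 (1.21 log units; beyond the scatter) as steps larger than any among compound 1, compound 2 and compound 3. Amino in place of methyl on the same phenyl ring gives an 84-fold lower number from compound 1 to compound 4 (1.93 log units; beyond the scatter) as the largest step shown, so one group on an otherwise unchanged ring is enough. Nothing available explains this drop.

Open, as far as these compounds go, is whether the step is specific to amino: a hydroxyl, a methoxy or a dimethylamino group on this ring would test that.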